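Methyl on an Aromatic Carbon in Two Related Cores

This account rests on a few compounds, and the source may have more. Where it says the series, first, only, none or still open, it means among the compounds named here.

Compound 1 `CN(CC1CCC/C(=C\c2ccccc2)C1=O)c1ccccc1` gives 69.7% in a functional assay on the whole organism (strain Kunming) for inhibition, with Mus musculus as the target, in the writhing test, with stated times of 1 h and 15 min, at a dose of 200 mg/kg by the oral route; a higher number here means more inhibition at the dose given (going by the name of the read-out), a lower number less inhibition. Compound 2 `Cc1ccc(/C=C2\CCCC(CN(C)c3ccccc3)C2=O)cc1` gives 68.2% in this assay, and the step of a number 1.5 percentage points lower from compound 1 to compound 2 (within the scatter) goes with the change (methyl in place of hydrogen on an aromatic carbon). Compound 3 `COc1ccc(C2(O)/C(=C/c3ccccc3)CCCC2CN(C)c2ccccc2)cc1` gives 75.7% in this assay; the difference between its core and the core of compound 1 is not broken down here. Compound 4 `COc1ccc(C2(O)/C(=C/c3ccc(C)cc3)CCCC2CN(C)c2ccccc2)cc1` has not been measured. Going by the values given here, it differs from compound 3 by methyl in place of hydrogen on an aromatic carbon, the same change as the one from compound 1 to compound 2. The step of a number 1.7 percentage points lower from compound 3 to compound 4 (within the scatter) is expected to be small, because a number 1.5 percentage points lower from compound 1 to compound 2 (within the scatter) was itself within the scatter. The estimate for compound 4 in this assay is 74%, with a range from 62% to 84%.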

Compound 4, a percentage reported as inhibition, in the whole organism at one dose (the size of the read-out at that dose, not a potency): 72.1%
Beside the measured number, compound 4's estimate is 1.9 percentage points above it; the measured number falls inside the stated range.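

Methyl in place of hydrogen on an aromatic carbon gives, in this assay, a number 3.6 percentage points lower from compound 3 to compound 4 (within the scatter) on the core of compound 3, and the step agrees with the one on the core of compound 1: the same change on two cores in this assay, a number 1.5 percentage points lower (within the scatter) from compound 1 to compound 2 and a number 3.6 percentage points lower (within the scatter) from compound 3 to compound 4, 2.1 percentage points apart, within the scatter of two such steps. Within these two pairs, the change therefore carries from one core to the other without a visible difference. This does not show that methyl itself alters the inhibition on either core, and two pairs read at one dose cannot establish a rule for other cores in the series.

What the compounds shown leave open is how other groups on that aromatic carbon would read, such as a chlorine atom, an amine or a carboxylic acid. They also leave open whether a longer chain there would give a step beyond the scatter.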